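The compounds below may be only part of what the source reports. "The series", "measured", "known", "first", "only" and "open" are said of these compounds alone.

Measured compounds:
Compound 1 `CC(=O)Nc1cc(C)c(CCS(=O)(=O)N2CCC3(CC2)N=C(C2CCCCC2)NC3=O)c(C)c1` gives 8 ug/mL in a physicochemical assay for solubility, read by HPLC, in phosphate buffer, at pH 6.5, tested at 1 mM; on this read-out higher numbers stand for higher solubility and lower numbers for lower solubility.
Compound 2 `Cc1cc(N(C)C(N)=O)cc(C)c1CCS(=O)(=O)N1CCC2(CC1)N=C(C1CCCCC1)NC2=O` gives 290 ug/mL in this assay.

For the measured compounds named here, compound 1 stands lowest of the two numbers so far; its nearest neighbour is compound 2, and the step of a 36-fold higher number from compound 1 to compound 2 (1.56 log units; beyond the scatter) separates them. Compound 3 `CC(=O)Nc1ccc(CCS(=O)(=O)N2CCC3(CC2)N=C(C2CCCCC2)NC3=O)c(C)c1` differs from compound 1 in a single place: hydrogen in place of methyl on an aromatic carbon, so that the position ortho to the large group now carries a hydrogen atom where compound 1 carries a methyl group.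

Going by the values given here, no measured step bears directly on this change. Among the compounds with values here, the only step recorded, a 36-fold higher number from compound 1 to compound 2 (1.56 log units; beyond the scatter), concerns a different group at a different site, the acetamido being replaced by carbamoyl(methyl)amino, and it says nothing about the loss of a methyl group from the ring. Within the data shown here, with no comparable step to draw on, the expectation is a small step in this assay, more likely upward than downward, and possibly not beyond the scatter at all. Compound 3 is therefore estimated at 15 ug/mL, within a range of 6 ug/mL to 40 ug/mL, which corresponds to an expected step of a 1.9-fold higher number from compound 1 to compound 3 (0.27 log units; within the scatter).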

Compound 3, solubility: 280 ug/mL
The estimate for compound 3 lay 19-fold (1.27 log units) below the measured number; measured number outside the range, above it.
By their numbers in this assay, from the lowest: compound 1; then compounds 3 and 2 (each within the scatter of the next).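

In this assay, the exchange of methyl for hydrogen ortho to a large group gives a 35-fold higher number from compound 1 to compound 3 (1.54 log units; beyond the scatter) and so shows that this position on the aromatic ring is far from silent: the group that leaves holds only one carbon, with no hydrogen-bond donors, no hydrogen-bond acceptors and no net charge. The earlier compounds had shown a large step only for the replacement of acetamido by carbamoyl(methyl)amino, a 36-fold higher number from compound 1 to compound 2 (1.56 log units; beyond the scatter), and this result adds a second place on the same ring where one change moves the number by a large step. Nothing in the evidence shown accounts for the step seen at this position.

The compounds shown leave open whether hydrogen is special here or whether a fluorine atom, a methoxy group or an amine at the same carbon would give a similar number. They also leave open what happens when the loss of this methyl group and the carbamoyl(methyl)amino group are combined in one compound, and whether the remaining methyl group, meta to the position studied here, behaves in the same way.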